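The source may report more compounds than this note shows. Statements on the series, on what has been measured and on what is new or still open speak of the compounds shown alone.

In a functional assay on SCC-7 cells (Mus musculus) for inhibition (a lower number here means a stronger inhibitor, a higher number a weaker inhibitor), compound 1 (`Nc1n[n+]([O-])c2c(Cl)cccc2[n+]1[O-]`) gives 450 nM and compound 2 (`CS(=O)(=O)c1cccc2c1[n+]([O-])nc(N)[n+]2[O-]`) gives 9700 nM on the same core. Compound 3 (`Nc1n[n+]([O-])c2cc(F)ccc2[n+]1[O-]`) gives 1100 nM and so stands second highest of the three. Compound 4 (`Nc1n[n+]([O-])c2cc([N+](=O)[O-])ccc2[n+]1[O-]`) carries nitro in place of fluoro on an aromatic carbon. Among the compounds with values here, only one measured step offers any guide, and it involves neither group: a 22-fold higher number from compound 1 to compound 2 (1.33 log units; beyond the scatter), a large rise with methylsulfonyl in place of chloro. On that thin evidence, a modest move towards weaker inhibition is expected, much smaller than that rise, and the direction remains uncertain. The expected step is a 2.3-fold higher number from compound 3 to compound 4 (0.36 log units; beyond the scatter) in this assay. For compound 4 the estimated value is 2500 nM, with an expected range from 400 nM to 12000 nM.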

Compound 4, half-maximal inhibitory concentration: 700 nM
Estimate against measurement, compound 4: 3.6-fold (0.55 log units) above; the range from low to high includes it.
By their numbers in this assay, from the lowest: compounds 1, 4 and 3 (each within the scatter of the next, the first and the last beyond it); then compound 2.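

In this assay, nitro in place of fluoro on this aromatic carbon, meta to a fused ring and para to a fused ring, gives a 1.6-fold lower number from compound 3 to compound 4 (0.20 log units; within the scatter) and so stays within the scatter. This position therefore accepts the exchange of one fluorine for the three heavy atoms of nitro with no resolved change, unlike the other measured exchange, which gives a 22-fold higher number from compound 1 to compound 2 (1.33 log units; beyond the scatter) with methylsulfonyl in place of chloro. No measurement at hand says why these two groups read alike.

From the compounds shown here alone, whether an amine or a carboxylic acid on the same carbon would also stay within the scatter remains open. So does whether nitro would give a similar number on the carbon that carries chloro in compound 1.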